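This account rests on a few compounds, and the source may have more. Where it says the series, first, only, none or still open, it means among the compounds named here.

Of the compounds shown here, three sharing one core have been measured in a physicochemical assay for solubility; on this read-out higher numbers stand for higher solubility and lower numbers for lower solubility. Compound 1, `COC(=O)c1ccc(NC(=O)c2cc3cc([N+](=O)[O-])ccc3o2)cc1`, gives 20 ug/mL; compound 2, `NC(=O)c1cccc(NC(=O)c2cc3cc([N+](=O)[O-])ccc3o2)c1`, gives 20 ug/mL; and compound 3, `O=C(Nc1ccccc1)c1cc2cc([N+](=O)[O-])ccc2o1`, gives 25 ug/mL. On these numbers compound 3 sits no further from its neighbours than the scatter allows: the step of a 1.3-fold higher number from compound 1 to compound 3 (0.10 log units; within the scatter) and the step of a 1.3-fold higher number from compound 2 to compound 3 (0.10 log units; within the scatter) both stay within it, so the three values are indistinguishable.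

Compound 4, `CC(C)(C)OC(=O)NCc1ccccc1NC(=O)c1cc2cc([N+](=O)[O-])ccc2o1`, differs from compound 3 by ((tert-butoxycarbonyl)amino)methyl in place of hydrogen on an aromatic carbon. The two measured steps both concern a group on an aromatic carbon of the same ring, and in each case the swap left this assay essentially unmoved. Neither step involves the group that enters here, nor a group at the place stated, so they bear on the question only loosely; what they do show is that decorating this ring has so far not shifted this assay beyond the scatter. On that basis a step of a 1.4-fold lower number from compound 3 to compound 4 (0.14 log units; within the scatter) is expected, that is, no change beyond the scatter, and compound 4 is estimated at 18 ug/mL, with a range from 7 ug/mL to 45 ug/mL.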

Compound 4, solubility: 25 ug/mL
Estimate against measurement, compound 4: 1.4-fold (0.14 log units) below, and the stated range covers the measured number.
By their numbers in this assay, from the lowest: compounds 1, 2, 3 and 4 (each within the scatter of the next).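

In this assay, putting ((tert-butoxycarbonyl)amino)methyl on an aromatic carbon, ortho to a large group, gives no change at the digits printed from compound 3 to compound 4 (within the scatter). The earlier steps shown here covered only methoxycarbonyl and carbamoyl, neither at this place, whereas this step shows that a chain of 9 heavy atoms, with no ring and no net charge, can sit ortho to a large group and leave the read-out within the scatter. No measurement at hand offers an explanation for this flat result.

The compounds shown leave open whether a smaller group at this same place, such as methyl, or the free aminomethyl group would also stay within the scatter. They also leave open whether a carboxylic acid or a longer amine chain here would move the read-out beyond it.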